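The source may report more compounds than this note shows. Statements on the series, on what has been measured and on what is new or still open speak of the compounds shown alone.

Measured compounds:
- compound 1 `CCOC(=O)N1CCN(CCCOc2ccc(C(C)=O)cc2)CC1`: 39800 nM
- compound 2 `CCOC(=O)N1CCN(CCCOc2ccc(C(=O)c3cccc(F)c3F)cc2)CC1`: 17400 nM

In an assay on isolated protein for binding affinity to histamine H2 receptor (Homo sapiens) (on this read-out lower numbers stand for stronger inhibition and higher numbers for weaker inhibition), compound 2 gives the lowest of the two numbers seen so far, its nearest neighbour being compound 1. For the measured compounds named here, the only measured step, a 2.3-fold lower number from compound 1 to compound 2 (0.36 log units; beyond the scatter), is modest. The next compound, compound 3 `CCOC(=O)N1CCN(CCCOc2ccc(C(=O)c3cccc(C)c3)cc2)CC1`, has not yet been measured. It differs from compound 2 in one place: 3-methylphenyl in place of 2,3-difluorophenyl on a carbonyl carbon. Both compounds thus carry an aromatic ring on the carbonyl carbon, and the measured step from compound 1 to compound 2 concerns the move from methyl to an aromatic ring rather than a swap of one aromatic ring for another, so it bears on this change only loosely. Going by the values given here, no measured step tells how one aromatic ring compares with another here. Compound 3 is therefore expected to sit close to compound 2, the estimated step being a 1.2-fold lower number from compound 2 to compound 3 (0.06 log units; within the scatter). The estimate for compound 3 in this assay is 15000 nM, with a range from 6000 nM to 40000 nM.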

Compound 3, inhibition constant: 3720 nM
The estimate for compound 3 lay 4.0-fold (0.61 log units) above the measured number; the whole stated range lies above it.
By their numbers in this assay, from the lowest: compound 3; then compound 2; then compound 1.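

In this assay, the aromatic ring on the carbonyl carbon proves not to be interchangeable: 3-methylphenyl in place of 2,3-difluorophenyl gives a 4.7-fold lower number from compound 2 to compound 3 (0.67 log units; beyond the scatter) and so separates two rings that the earlier comparison with methyl could not tell apart. Measured against methyl on the same carbonyl carbon, 3-methylphenyl gives an 11-fold lower number from compound 1 to compound 3 (1.03 log units; beyond the scatter) and is the only change shown here that reaches a large step. Nothing measured here explains why one aromatic ring gives a lower number than the other.

On these data alone, whether the lower number goes with the added methyl or with the loss of both fluorines stays open. Also open, as far as these compounds go, is how plain phenyl, 3-chlorophenyl or 3-methoxyphenyl on the carbonyl carbon would compare with 3-methylphenyl.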